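Ester-to-amide change on the carbonyl carbon of compound 1

A few compounds are considered here, and "the series" means these few. Any claim that something is new, unique, unknown or untested is made for them only; others in the source may bear on it.

Two members of the series have been measured in an ADME assay on microsomes from liver (Homo sapiens) for metabolic stability, read by LC-MS, using NADPH, with a stated time of 45 min, tested at 1 uM; on this read-out higher numbers stand for a longer-lived compound and lower numbers for a shorter-lived compound. Compound 1 `COCCOC(=O)c1cc(N)c(Nc2ccc(C#N)cc2)cc1Oc1c(C)cc(/C=C/C#N)cc1C` gives 0.317 h, the lowest of the two numbers. Compound 2 `Cc1cc(/C=C/C#N)cc(C)c1Oc1cc(Nc2ccc(C#N)cc2)c(N)cc1C(=O)N1CC1` gives 2.63 h. Going by the values given here, the only step so far, an 8.3-fold higher number from compound 1 to compound 2 (0.92 log units; beyond the scatter), comes from aziridin-1-yl in place of 2-methoxyethoxy on a carbonyl carbon.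

Compound 3 `CNC(=O)c1cc(N)c(Nc2ccc(C#N)cc2)cc1Oc1c(C)cc(/C=C/C#N)cc1C` is not yet measured. It differs from compound 1 by methylamino in place of 2-methoxyethoxy on a carbonyl carbon. This change sits at the same carbonyl carbon as the measured step, and like it removes the 2-methoxyethoxy group, so the step from compound 1 to compound 2 is the one that bears on it. An increase in this assay is therefore expected, probably of the same order as that step but with wide uncertainty, since no second replacement at this carbonyl carbon has been measured. For compound 3 the estimated step is a 5.7-fold higher number from compound 1 to compound 3 (0.75 log units; beyond the scatter). The expected value for compound 3 is 1.8 h, within a range from 0.7 h to 4.5 h.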

Compound 3, half-life: 1.87 h
For compound 3 the middle estimate is 1.0-fold (0.02 log units) below the measured one; low and high end bracket the measured number.
By their numbers in this assay, from the lowest: compound 1; then compounds 3 and 2 (each within the scatter of the next).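

In this assay a second replacement of 2-methoxyethoxy on the carbonyl carbon gives a 5.9-fold higher number from compound 1 to compound 3 (0.77 log units; beyond the scatter), so the higher number no longer rests on aziridin-1-yl alone: both amides, compound 2 and compound 3, stand clear of the ester, compound 1. Between the two amides the data show a 1.4-fold lower number from compound 2 to compound 3 (0.15 log units; within the scatter), which is within the scatter, so methylamino and aziridin-1-yl cannot be told apart on this read-out. Nothing available explains the difference between the ester and the amides.

As far as these compounds go, it remains open whether the higher number follows from the nitrogen on the carbonyl carbon or from the loss of the 2-methoxyethoxy chain. A methoxy ester and a 2-methoxyethylamino amide at this carbonyl carbon would separate those two readings.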